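Pyridinyl for furanyl on the amide nitrogen side chain

A few compounds are considered here, and "the series" means these few. Any claim that something is new, unique, unknown or untested is made for them only; others in the source may bear on it.

Going by the values given here, compound 1 `CCN(Cc1ccoc1)C(=O)COc1ccc(C)cc1` gives 136 nM in an assay on HEK293 cells for agonist activity at transient receptor potential cation channel subfamily M member 8 (Homo sapiens), read by fluorescence and calcium flux, with a stated time of 15 min (a higher number here means that more compound is needed for the effect, a lower number that less compound is needed), and stands second highest of the three numbers known. Compound 2 `Cc1ccc2oc(C(=O)N(Cc3cccs3)c3ccn[nH]3)cc2c1` gives 40 nM in this assay, a gap beyond the scatter. Compound 3 `CCN(Cc1cccs1)C(=O)COc1ccc2c(c1)CCCC2` gives 689 nM in this assay, also beyond the scatter from compound 1. The change to compound 4 `CCN(Cc1ccccn1)C(=O)COc1ccc(C)cc1` is pyridin-2-yl in place of furan-3-yl on a saturated chain carbon bound to an amide-type nitrogen. Among the compounds with values here, no measured pair shows this change; compound 2 and compound 3 carry a different five-membered group and do not inform it. The step of a 1.5-fold higher number from compound 1 to compound 4 (0.17 log units; within the scatter) is expected to be small, toward a slightly higher number, within the scatter. Compound 4 is estimated at 200 nM in this assay, in a range of 70 nM to 600 nM.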

Compound 4, half-maximal effective concentration: 16000 nM
Compound 4: the middle estimate sits 80-fold (1.90 log units) below what was measured, outside the stated range (above it).
By their numbers in this assay, from the lowest: compound 2; then compound 1; then compound 3; then compound 4.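

In this assay the place on a saturated chain carbon bound to an amide-type nitrogen responds sharply: pyridin-2-yl in place of furan-3-yl brings a 120-fold higher number from compound 1 to compound 4 (2.07 log units; beyond the scatter). Both groups count one hetero atom and one hydrogen-bond acceptor, so these counts do not separate them. Nothing available bears on the reason for this step.

As far as these compounds go, whether the step follows the six-membered ring or the ring nitrogen remains open. Phenyl and pyridin-3-yl at this place would separate the two readings.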